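A few compounds are considered here, and "the series" means these few. Any claim that something is new, unique, unknown or untested is made for them only; others in the source may bear on it.

Compound 1 `CCc1ccc2[nH]c(=O)c(CN(Cc3ccc(F)cc3)Cc3ccc(C(C)(C)C)cc3)cc2c1`: in a toxicity assay on MDCK cells (Canis lupus familiaris) for cytotoxicity, read by crystal violet staining, with a stated time of 48 h (on this read-out lower numbers stand for higher toxicity in this test and higher numbers for lower toxicity in this test), compound 1 sits at the limit > 33000 nM.
Compound 2 `CCc1ccc2[nH]c(=O)c(CN(Cc3ccc(O)cc3)Cc3ccc(C(C)(C)C)cc3)cc2c1`: in this assay compound 2 sits at the limit > 10000 nM.
Compound 3 `CCc1ccc2[nH]c(=O)c(CN(Cc3ccc(C(C)(C)C)cc3)C(C)c3ccc(F)cc3)cc2c1`: in this assay compound 3 gives 2800 nM.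

Going by the values given here, compound 3 holds the only number among the three; the values of compound 1 and compound 2 are limits of the test, as set out in the limit of > 33000 nM in this assay, at which 1 of the 3 values shown sits, and (the limit of > 10000 nM in this assay, at which 1 of the 3 values shown sits). The step of an at least 11-fold lower number from compound 1 to compound 3 (1.07 log units; beyond the scatter) and the step of an at least 3.5-fold lower number from compound 2 to compound 3 (0.55 log units; beyond the scatter) are both read against those limits, so each is known only as a lower bound of its size. The step that the two limits leave unreadable from compound 1 to compound 2 cannot be sized at all, as both ends are limits.

Compound 4 `CCc1ccc2[nH]c(=O)c(CN(Cc3ccc(C(C)(C)C)cc3)C(C)c3ccc(OC)cc3)cc2c1` differs from compound 3 by methoxy in place of fluoro on an aromatic carbon. Among the compounds with values here, no measured step covers this exchange. Within the data shown here, the only step that touches the same aromatic carbon, the one from compound 1 to compound 2, is unreadable between two limits and gives no guidance. The methyl on the saturated chain carbon, which separates compound 3 from compound 1 and compound 2, is kept in compound 4. The expectation is therefore no step beyond the scatter, no change at the digits printed from compound 3 to compound 4 (within the scatter), in this assay. Compound 4 is estimated at 2800 nM, within 1000 nM to 8000 nM.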

Compound 4, half-maximal cytotoxic concentration: > 5000 nM
Compound 4: no number, only a limit; the forecaster's own chance of this, stated with the estimate: 20%; middle value at least 1.7-fold (0.25 log units) away from the limit.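

In this assay compound 4 carries a limit of the test and not a number: the limit of > 5000 nM in this assay, at which 1 of the 4 values shown sits. Going by these compounds alone, with the methyl on the saturated chain carbon kept, methoxy in place of fluoro gives the first exchange at this aromatic carbon, para to a large group, that can be read at all: an at least 1.7-fold higher number from compound 3 to compound 4 (0.25 log units; that floor lies within the scatter); the printed floor of that step does not establish a change, but the limit of compound 4 does show that methoxy here gives no number lower than that of the fluoro compound. The steps from compound 1 and from compound 2 to compound 4 cannot be read, as both ends of each are limits, so the two unmethylated compounds add nothing to this comparison.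

As far as these compounds go, how far the value of compound 4 lies past its limit stays open, and with it whether the exchange has any real size in this read-out. Also open is how an amine or a carboxylic acid on this aromatic carbon would read with the methyl on the chain carbon kept, since only fluoro and methoxy are shown there in that setting.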